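Oxadiazole aryl swap at the shared core, growth inhibition

A few compounds are considered here, and "the series" means these few. Any claim that something is new, unique, unknown or untested is made for them only; others in the source may bear on it.

Measured compounds:
compound 1 `CS(=O)(=O)c1ccc(-c2cnc3[nH]cc(-c4nnc(-c5ccc(F)cc5)o4)c(=O)c3c2)cc1`, 7.58%
compound 2 `N#Cc1ccc(-c2cnc3[nH]cc(-c4nnc(-c5ccc(Cl)cc5)o4)c(=O)c3c2)cc1`, 9.73%
compound 3 `O=c1c(-c2nnc(-c3ccc(Cl)cc3)o2)c[nH]c2ncc(-c3ccccc3)cc12`, 19.5%

In a functional assay on KB cells (Homo sapiens) for inhibition, read by MTT assay, with a stated time of 24 h, tested at 10 uM (a higher number here means more inhibition of growth at the concentration tested, a lower number less inhibition of growth), compound 1 gives 7.58%. Compound 2, with its 9.73%, cannot be told apart from compound 1, the gap between them lying within the scatter. Compound 3 gives 19.5%, and that gap to compound 1 lies beyond the scatter; whether the hydrogen on the pendant phenyl or the chlorine on the oxadiazole aryl carries it cannot be read from two values alone.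

Compound 4 `Cc1cccc(-c2nnc(-c3c[nH]c4ncc(-c5ccc(S(C)(=O)=O)cc5)cc4c3=O)o2)c1` differs from compound 1 in one place: 3-methylphenyl in place of 4-fluorophenyl on an aromatic carbon. For the measured compounds named here, no measured step touches this position. Going by the values given here, the only measured step, a number 9.8 percentage points higher from compound 2 to compound 3 (within the scatter), concerns the other aryl of the core and stayed within the scatter. There is therefore no ground to expect a shift beyond the scatter in this assay for compound 4. The estimate for compound 4 is 10%, with a range from 0% to 25%, which is expected to mean a step of a number 2.4 percentage points higher from compound 1 to compound 4 (within the scatter).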

Compound 4, percent growth inhibition at one concentration: 7.5%
Compound 4: the middle estimate sits 2.5 percentage points above what was measured, and the stated range covers the measured number.
By their numbers in this assay, from the lowest: compounds 4, 1, 2 and 3 (each within the scatter of the next, the first and the last beyond it).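

In this assay, for the compounds shown here, the first measured change on the aromatic carbon of the five-membered aromatic ring with 2 nitrogen and 1 oxygen, 3-methylphenyl in place of 4-fluorophenyl, gives a number 0.1 percentage points lower from compound 1 to compound 4 (within the scatter) and so no readable shift. Going by these compounds alone, the earlier step concerned only the other aryl of the core, so this is the first reading at this position, and it holds for one pair that shares the same other aryl. No measured property or other data bear on this result.

Still open, on these data alone, is whether an amine or a carboxylic acid on this aryl, or a longer alkyl chain in its place, would move the number beyond the scatter. Also open, as far as these compounds go, is whether 3-methylphenyl would give the same reading with the other aryl of the core as in compound 3.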